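A few compounds are considered here, and "the series" means these few. Any claim that something is new, unique, unknown or untested is made for them only; others in the source may bear on it.

Measured so far:
compound 1 `Cn1ccc2ccc(-c3cc(Nc4ccccc4S(=O)(=O)Nc4cncnc4)cc4nccnc34)cc21` gives > 100000 nM
compound 2 `CN(Cc1cncnc1)S(=O)(=O)c1ccccc1Nc1cc(-c2ccc3ccn(C)c3c2)c2nccnc2c1` gives > 100000 nM
compound 3 `CC(=O)N1CCC(NC(=O)c2ccncc2Nc2cc(-c3ccc4ccn(C)c4c3)c3nccnc3c2)CC1` gives 31300 nM

Of the compounds shown here, three with a shared core have been tested in an assay on lysate for inhibition of 6-phosphofructo-2-kinase/fructose-2,6-bisphosphatase 3 (Homo sapiens), with stated times of 0.5 min and 45 min; a lower number here means a stronger inhibitor, a higher number a weaker inhibitor. For compound 1 the result is only a limit, > 100000 nM, not a number. For compound 2 the result is likewise only a limit, > 100000 nM. For the measured compounds named here, the single change between them, a step that the two limits leave unreadable from compound 1 to compound 2, therefore cannot be read. Going by the values given here, compound 3 is the one compound with a number, 31300 nM. The other two values sit at the limit of > 100000 nM in this assay, at which 2 of the 3 values shown sit.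

Compound 4 `CC(=O)N1CC(CNC(=O)c2ccncc2Nc2cc(-c3ccc4ccn(C)c4c3)c3nccnc3c2)C1` has not yet been measured. It differs from compound 3 in one place: (1-acetylazetidin-3-yl)methyl in place of 1-acetylpiperidin-4-yl on an amide-type nitrogen. Among the compounds with values here, no measured step touches this part of the molecule, and the one measured step sits on a sulfonyl sulfur and is unreadable between two limits, so nothing in the data sets a size or a direction for this change. The step expected in this assay, a 1.1-fold higher number from compound 3 to compound 4 (0.05 log units; within the scatter), is therefore taken to stay within the usual scatter. Compound 4 is estimated at 35000 nM, in a range from 10000 nM to 120000 nM.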

Compound 4, half-maximal inhibitory concentration: > 100000 nM
Compound 4: a limit, no number (the forecaster's own chance of this, stated with the estimate: 25%); at least 2.8-fold (0.45 log units) between middle value and limit.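

In this assay, putting (1-acetylazetidin-3-yl)methyl in place of 1-acetylpiperidin-4-yl on the amide-type nitrogen gives an at least 3.1-fold higher number from compound 3 to compound 4 (0.50 log units; beyond the scatter). Compound 4 gives > 100000 nM, which is a limit of the assay and not a number. This is the first readable step in the series, and it shows that the group on this nitrogen affects the read-out even when the acetyl group is kept and only the ring and its link change, leaving most of the values shown at one ceiling: the limit of > 100000 nM in this assay, at which 3 of the 4 values shown sit.

From the compounds shown here alone, how far the number rises from compound 3 to compound 4 stays unknown, and the step from compound 1 to compound 2 still cannot be read. Also open, going by these compounds, is whether a free amine in place of the acetyl group, or a carboxylic acid on a longer chain at this nitrogen, would give a lower number.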